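A few compounds are considered here, and "the series" means these few. Any claim that something is new, unique, unknown or untested is made for them only; others in the source may bear on it.

Measured compounds in the series:
- compound 1, `CNC(=O)c1cc(Oc2ccc(NC(=O)c3nn(-c4ccccc4F)c(=O)cc3C)cc2F)ccn1`
- compound 2, `Cc1cc(=O)n(-c2ccccc2OC(F)(F)F)nc1C(=O)Nc1ccc(Oc2ncnc3sccc23)cc1`
- compound 3, `O=C(Nc1ccc(Oc2ncnc3ccsc23)c(F)c1)c1nn(-c2ccc(Br)cc2)ccc1=O`

In a functional assay on A549 cells (Homo sapiens) for cytotoxicity, read by MTT assay, with a stated time of 72 h (a lower number here means a stronger inhibitor, a higher number a weaker inhibitor), compound 1 gives only a limit, > 40000 nM, and no number. In this assay compound 2 gives 15500 nM. Compound 3 gives 7840 nM in this assay. On the two numbers shown, compound 3 has the lowest number, but its nearest neighbour compound 2 lies within the scatter of it, so no order between these two can be claimed; compound 1 sits at the limit, which is where the limit of > 40000 nM in this assay, at which 1 of the 3 values shown sits, applies.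

Compound 4, `Cc1ccc(-n2ccc(=O)c(C(=O)Nc3ccc(Oc4ncnc5ccsc45)c(F)c3)n2)cc1`, has not yet been measured in this assay. It differs from compound 3 in one place: methyl in place of bromo on an aromatic carbon, para to a large group; read one bond further out, 4-bromophenyl becomes 4-methylphenyl. For the measured compounds named here, no step between two measured compounds covers this exchange, so there is nothing to scale it by. The expectation is a step from compound 3 to compound 4 of a 1.1-fold higher number from compound 3 to compound 4 (0.06 log units; within the scatter), that is, no change beyond the scatter in either direction. For compound 4 the estimated value in this assay is 9000 nM, with a range from 3000 nM to 30000 nM.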

Compound 4, half-maximal inhibitory concentration: 11600 nM
Beside the measured number, compound 4's estimate is 1.3-fold (0.11 log units) below it; measured number inside the range.
By their numbers in this assay, from the lowest: compounds 3, 4 and 2 (each within the scatter of the next). At a limit, above all of these: compound 1.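

In this assay, for the compounds shown here, the pair gives a 1.5-fold higher number from compound 3 to compound 4 (0.17 log units; within the scatter) and so provides the first reading at this position: methyl in place of bromo on an aromatic carbon, para to a large group, leaves the number within the scatter. The 4-bromophenyl and 4-methylphenyl compounds therefore cannot be ordered, and on this single pair the exchange of one heavy atom for another at this place has no readable effect on the cytotoxicity read-out. No measured property at hand bears on why the two compounds read alike.

One pair cannot show how much this position tolerates: an amine, a carboxylic acid or a longer chain at the same place, or a phenyl carrying no group there, would put the flat reading to a harder test. Going by these compounds, whether methyl in place of bromo also reads flat on the other cores stays open, as does whether any exchange at this place can move the number beyond the scatter.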